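3-(Trifluoromethyl)phenyl in Place of Naphthalen-1-yl: an Expected Step

This account rests on a few compounds, and the source may have more. Where it says the series, first, only, none or still open, it means among the compounds named here.

Three compounds were tested in a functional assay on CHO cells for agonist activity at Free fatty acid receptor 1 (Homo sapiens), read by FLIPR and calcium flux, tested at 100 nM; on this read-out higher numbers stand for a stronger effect at the one concentration tested and lower numbers for a weaker effect. Compound 1 `O=C(O)CC1COc2cc(OCc3ncc(-c4ccccc4)o3)ccc21` gives 2.34%, compound 2 `O=C(O)CC1COc2cc(OCc3csc(-c4ccccc4)n3)ccc21` gives 0.15%, and compound 3 `Cc1nc(-c2cccc3ccccc23)sc1COc1ccc2c(c1)OCC2CC(=O)O` gives 8.53%, the highest of the three numbers, although its gaps to compound 1 and to compound 2 both lie within the scatter. Compound 4 `Cc1nc(-c2cccc(C(F)(F)F)c2)sc1COc1ccc2c(c1)OCC2CC(=O)O` has not yet been measured; it differs from compound 3 in one place: 3-(trifluoromethyl)phenyl in place of naphthalen-1-yl on an aromatic carbon. Among the measured compounds shown here, no step between measured compounds is available, so the expectation rests on the low number of compound 3 at 8.53%. A step of no size beyond the scatter is expected, leaning slightly downward. Compound 4 is expected to give about 5% in this assay, within 0% to 18%, an estimated step of a number 3.5 percentage points lower from compound 3 to compound 4 (within the scatter).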

Compound 4, a percentage reported as activity, at one concentration (the size of the read-out at that concentration, not a potency): 35.7%
The estimate for compound 4 lay 30.7 percentage points below the measured number, outside the stated range (above it).
By their numbers in this assay, from the lowest: compounds 2, 1 and 3 (each within the scatter of the next); then compound 4.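

Replacing naphthalen-1-yl with 3-(trifluoromethyl)phenyl, on the aromatic carbon next to the ring nitrogen and next to the ring sulfur, gives in this assay a number 27.2 percentage points higher from compound 3 to compound 4 (beyond the scatter) and so shows that the group at this position can move the read-out. The change keeps the count of heavy atoms and leaves one aromatic ring in place of two. Nothing measured here explains the step. The compounds shown leave open whether a nitrile or a methoxy group in place of the trifluoromethyl would give a similar number.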